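This account rests on a few compounds, and the source may have more. Where it says the series, first, only, none or still open, it means among the compounds named here.

In an ADME assay on microsomes from liver (Rattus norvegicus) for metabolic stability, with a stated time of 10 min, tested at 0.5 uM (a lower number here means that less of the compound is left, a higher number that more of the compound is left), compound 1 (`CC(C)Cc1ccc(-c2cn(C)c3cc(C(=O)NS(C)(=O)=O)ccc23)cc1`) gives 94% of compound left, while compound 2 (`Cn1cc(-c2ccc(C(F)(F)F)cc2)c2cc(F)c(C(=O)NS(=O)(=O)C3CC3)cc21`) gives 100% of compound left and compound 3 (`CC(C)COc1ccc(-c2nn(C)c3cc(C(=O)NS(=O)(=O)C4CC4)c(F)cc23)cn1`) gives 88% of compound left. Compound 2 lies within the scatter of compound 1 and beyond the scatter above compound 3.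

Compound 4 (`Cn1cc(-c2ccc(C(F)(F)F)cc2)c2ccc(C(=O)NS(=O)(=O)C3CC3)cc21`) has no number yet. It departs from compound 2 as follows: hydrogen in place of fluoro on an aromatic carbon (hydrogen in place of fluoro on an aromatic carbon, ortho to a (cyclopropylsulfonyl)carbamoyl group).

Going by the values given here, no measured pair isolates this change. Compound 1 carries no fluoro on the shared core and gives 94% of compound left, though it also differs from compound 2 elsewhere. On that limited evidence, no step beyond the scatter is expected in this assay for this change. The estimated move is a number 6 percentage points lower from compound 2 to compound 4 (within the scatter) and lies within the scatter. For compound 4 the expected value is 94% with an estimated range from 84% to 100% of compound left.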

Compound 4, percent of the compound remaining: 92%
Compound 4: middle estimate off by 2 percentage points, on the high side; measured number inside the range.
By their numbers in this assay, from the lowest: compounds 3, 4, 1 and 2 (each within the scatter of the next, the first and the last beyond it).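

Hydrogen in place of fluoro on an aromatic carbon, ortho to a (cyclopropylsulfonyl)carbamoyl group, now has a direct reading in this assay: a number 8 percentage points lower from compound 2 to compound 4 (within the scatter). Until now, this position could be judged only through compound 1, which also differs from compound 2 elsewhere; with everything else held constant, the read-out does not separate the fluoro and hydrogen forms. No independent data bear on why this position behaves as it does.

From the compounds shown here alone, what a chloro, a methoxy or a nitrile at this place would give remains open. Going by these compounds, it is also open whether the same exchange would read alike in the setting of compound 3, which differs from compound 2 in several places.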